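The source may report more compounds than this note shows. Statements on the series, on what has been measured and on what is new or still open speak of the compounds shown alone.

Measured so far:
- compound 1, `Cn1ncc2c(=O)n(-c3ccccc3)c(COc3cccc(F)c3)nc21`: 8200 nM
- compound 2, `Cn1ncc2c(=O)n(-c3ccccc3)c(SC(C)(C)c3ccccc3)nc21`: 1900 nM

In an assay on isolated protein for inhibition of aldehyde dehydrogenase 1A1 (Homo sapiens) (on this read-out lower numbers stand for stronger inhibition and higher numbers for weaker inhibition), compound 1 gives 8200 nM, the highest of the two numbers shown, and in this assay compound 2 gives 1900 nM, a lower number that lies beyond the usual scatter. For the measured compounds named here, the two differ in more than one place, so their values say only that compound 2 inhibits more strongly. Compound 3, `Cn1ncc2c(=O)n(-c3ccccc3)c(CSc3cccc(F)c3)nc21`, has not yet been measured. It differs from compound 1 by (3-fluorophenyl)sulfanyl in place of 3-fluorophenoxy on a saturated chain carbon bound to an aromatic carbon, so the group it carries keeps the same ring and the same fluorine. Going by the values given here, no measured pair shows the oxygen-to-sulfur change alone, so a clear direction cannot be read from what exists. The step from compound 1 to compound 3 in this assay is expected to be small, a 1.6-fold lower number from compound 1 to compound 3 (0.21 log units; within the scatter), possibly within the scatter. Compound 3 is estimated at 5000 nM, between 1500 nM and 16000 nM.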

Compound 3, half-maximal inhibitory concentration: 720 nM
Estimate against measurement, compound 3: 6.9-fold (0.84 log units) above; the whole stated range lies above it.
By their numbers in this assay, from the lowest: compound 3; then compound 2; then compound 1.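

In this assay, putting (3-fluorophenyl)sulfanyl in place of 3-fluorophenoxy gives an 11-fold lower number from compound 1 to compound 3 (1.06 log units; beyond the scatter), so inhibition is sensitive to this change on the saturated chain carbon bound to an aromatic carbon. The two groups share the same ring, the same fluorine and the same number of heavy atoms, and they differ only in having sulfur instead of oxygen, so a single-atom exchange is enough to move the number well beyond the usual scatter. No available evidence explains this step.

The compounds shown leave open whether an amine nitrogen in place of the sulfur, or a longer chain carrying the same ring, would keep this stronger inhibition. They also leave open how a plain phenylsulfanyl group, without the fluorine, would compare with compound 3.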